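The compounds below may be only part of what the source reports. "The series", "measured", "known", "first", "only" and "open" are said of these compounds alone.

Two measured compounds set the scene. In an assay on isolated protein for inhibition of thyroid hormone receptor beta (Homo sapiens), read by fluorescence, with a stated time of 30 min (on this read-out lower numbers stand for stronger inhibition and higher numbers for weaker inhibition), compound 1 `COc1cc(C(=O)N2CC[C@@H](O)C(C)(C)C2)cc2nc(NCc3cccc(Cl)c3)oc12` gives 35 nM, the lowest of the two numbers; compound 2 `COc1cc(C(=O)N2CCC(O)C(C)C2)cn2nc(NCc3cccc(Cl)c3)nc12` gives 470 nM, a higher number that lies beyond the scatter. Compound 3 `COc1cc(C(=O)N2CC(C)C(O)CC2CCO)cc2nc(NCc3cccc(Cl)c3)oc12` differs from compound 1 in one place: 4-hydroxy-2-(2-hydroxyethyl)-5-methylpiperidin-1-yl in place of 4-hydroxy-3,3-dimethylpiperidin-1-yl on a carbonyl carbon. Within the data shown here, no measured pair shows this change, so any expectation rests on compound 1 alone. The step of a 2.9-fold higher number from compound 1 to compound 3 (0.46 log units; beyond the scatter) is expected to be a modest loss, somewhat beyond the scatter, with the direction uncertain. Compound 3 is therefore estimated at 100 nM, within a range from 25 nM to 400 nM.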

Compound 3, half-maximal inhibitory concentration: 0.27 nM
The estimate for compound 3 lay 370-fold (2.57 log units) above the measured number; the measured number lies below the stated range.
By their numbers in this assay, from the lowest: compound 3; then compound 1; then compound 2.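

In this assay, the group on the carbonyl carbon proves to matter a great deal: 4-hydroxy-2-(2-hydroxyethyl)-5-methylpiperidin-1-yl in place of 4-hydroxy-3,3-dimethylpiperidin-1-yl gives a 130-fold lower number from compound 1 to compound 3 (2.11 log units; beyond the scatter). So this position accepts a larger piperidine group, and inhibition becomes much stronger. No available evidence accounts for this gain. Going by these compounds, the change alters several features at once, so it remains open whether the 2-hydroxyethyl group, the methyl group or their combination matters. Also open, on these data alone, is whether an amine, a carboxylic acid or a longer chain in place of the 2-hydroxyethyl group would keep the gain.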